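Dropping One Methoxy Group: From Compound 1 to Compound 4

The compounds below may be only part of what the source reports. "The series", "measured", "known", "first", "only" and "open" are said of these compounds alone.

Compound 1 `COc1cc(-c2cc(/C=C/C(=O)c3ccc(N)cc3)[nH]n2)cc(OC)c1OC` was tested in a functional assay on COLO 205 cells (Homo sapiens) for inhibition, read by sulforhodamine B assay, with a stated time of 48 h (a higher number here means a weaker inhibitor of growth, a lower number a stronger inhibitor of growth), where it gave 3340 nM. Among the three compounds measured so far that is the second highest number. Compound 2 `COc1ccc(-c2cc(/C=C/C(=O)c3ccc(OC)c(OC)c3)[nH]n2)cc1` gave 3300 nM, a value within the scatter of that of compound 1, so the two cannot be told apart. Among the measured compounds shown here, compound 3 `COc1cc(-c2cc(/C=C/C(=O)c3ccc(Cl)c(Cl)c3)[nH]n2)cc(OC)c1OC` gave 15800 nM; the single one-place step, a 4.7-fold higher number from compound 1 to compound 3 (0.67 log units; beyond the scatter), concerns the group on the carbonyl carbon, not the ring from which the methoxy group is now removed.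

Compound 4 `COc1ccc(-c2cc(/C=C/C(=O)c3ccc(N)cc3)[nH]n2)cc1OC` differs from compound 1 in a single place: hydrogen in place of methoxy on an aromatic carbon. For the measured compounds named here, no measured step touches this part of the molecule, so there is nothing to scale an expectation by, and compound 2, which carries fewer methoxy groups on that ring, also differs from compound 1 elsewhere and gives no clean comparison. Going by the values given here, with no bearing step, the expected change is none beyond the scatter. Compound 4 is therefore estimated at 4000 nM, with a range from 1500 nM to 11000 nM. That estimate means a step of a 1.2-fold higher number from compound 1 to compound 4 (0.08 log units; within the scatter) is expected.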

Compound 4, concentration for total growth inhibition: 3590 nM
Beside the measured number, compound 4's estimate is 1.1-fold (0.05 log units) above it; the measured number falls inside the stated range.
By their numbers in this assay, from the lowest: compounds 2, 1 and 4 (each within the scatter of the next); then compound 3.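

In this assay, hydrogen in place of methoxy on an aromatic carbon gives a 1.1-fold higher number from compound 1 to compound 4 (0.03 log units; within the scatter) and so the loss of this one methoxy group cannot be told apart from the scatter. Among the compounds shown here, this is the first measured step at this position, as the only earlier step, a 4.7-fold higher number from compound 1 to compound 3 (0.67 log units; beyond the scatter), concerns the group on the carbonyl carbon. No measurement is at hand that could explain this result.

The compounds shown leave open whether other groups at this position, such as a hydroxyl group, a fluorine atom or a longer ethoxy chain, would give a number like that of compound 1. They also leave open whether removing this methoxy group would give as small a step with the 3,4-dichlorophenyl group of compound 3 on the carbonyl carbon.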